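The source may report more compounds than this note shows. Statements on the series, on what has been measured and on what is new or still open speak of the compounds shown alone.

Measured so far in a functional assay on HCT-116 cells (Homo sapiens) for cytotoxicity, read by MTT assay, with a stated time of 48 h; a lower number here means a stronger inhibitor, a higher number a weaker inhibitor:
compound 1 `O=C(/C=C\Nc1ccc(F)cc1)c1nc(-c2ccc(F)cc2)n2ccccc12` gives > 30000 nM, a limit of the assay.
compound 2 `COc1ccc(-c2nc(C(=O)/C=C\Nc3ccc(Cl)cc3)c3ccccn23)cc1` gives > 30000 nM, a limit of the assay.
compound 3 `COc1ccc(N/C=C\C(=O)c2nc(-c3ccc(OC)cc3)n3ccccc23)cc1` gives > 30000 nM, a limit of the assay.

For the measured compounds named here, compound 3 therefore stands only at a limit in this assay, and the two other values shown are limits as well; the only single-point step among them, a step that the two limits leave unreadable from compound 2 to compound 3, cannot be read. Compound 4 `COc1ccc(-c2nc(C(=O)/C=C\Nc3ccc(F)cc3)c3ccccn23)cc1` differs from compound 3 by fluoro in place of methoxy on an aromatic carbon. Going by the values given here, no measured step bears readably on this change: the one measured step runs from two limits, and compound 1, which carries fluoro on both aromatic rings, also sits at a limit, as summed up by the limit of > 30000 nM in this assay, at which 3 of the 3 values shown sit. No step beyond the scatter is expected in this assay for the change to fluoro. Compound 4 is expected to give about 50000 nM, within 20000 nM to 200000 nM, and most probably to be reported again as a limit rather than a number. The step that the limit leaves unreadable from compound 3 to compound 4 that this estimate means is expected to lie within the scatter.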

Compound 4, half-maximal inhibitory concentration: > 30000 nM
Compound 4: no number, only a limit (the forecaster's own chance of this, stated with the estimate: 85%); the middle value is on the limit's open side.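

In this assay compound 4 gives > 30000 nM, a limit of the assay, so its steps from compound 1, compound 2 and compound 3 cannot be read. The compounds shown leave open whether fluoro, chloro and methoxy differ at all, and what on the shared core would give a measurable value: the limit of > 30000 nM in this assay, at which 4 of the 4 values shown sit.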